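From Cyclohexyl to 4-Acetoxyphenyl: An Expected Gain

The source may report more compounds than this note shows. Statements on the series, on what has been measured and on what is new or still open speak of the compounds shown alone.

Of the compounds shown here, three sharing one core have been measured in a functional assay for antagonist activity at Adrenergic receptor alpha-1 (Rattus norvegicus); on this read-out lower numbers stand for tighter binding and higher numbers for weaker binding. Compound 1 `COc1cccc(OC)c1OCCNC[C@H]1Oc2ccccc2O[C@H]1C1CCCCC1` gives 631 nM, compound 2 `COc1cccc(OC)c1OCCNC[C@H]1Oc2ccccc2O[C@@H]1C1CCCCC1` gives 813 nM, and compound 3 `CCc1ccc([C@@H]2Oc3ccccc3O[C@@H]2CNCCOc2c(OC)cccc2OC)cc1` gives 58.9 nM. Compound 2 holds the highest of the three numbers; its nearest neighbour is compound 1, with a 1.3-fold higher number from compound 1 to compound 2 (0.11 log units; within the scatter), a step that is within the scatter and rests on (the fact that compounds 1 and 2 differ only in the configuration as drawn). Its furthest neighbour is compound 3, whose number is well below that of compound 2.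

Compound 4 `COc1cccc(OC)c1OCCNC[C@H]1Oc2ccccc2O[C@@H]1c1ccc(OC(C)=O)cc1` has not yet been measured in this assay. Relative to compound 2 the change is 4-acetoxyphenyl in place of cyclohexyl on a saturated ring carbon. For the measured compounds named here, the one measured step that bears on this change is the exchange of the same cyclohexyl for a ring of the same kind in compound 3, which gave an 11-fold lower number from compound 1 to compound 3 (1.03 log units; beyond the scatter). The 4-acetoxyphenyl entering compound 4 differs from 4-ethylphenyl in its substituent, so the size of the step is less certain, but a clearly lower number is expected in this assay.

Compound 4 is therefore estimated at 90 nM, in a range from 25 nM to 320 nM, which would mean an expected step of a 9.0-fold lower number from compound 2 to compound 4 (0.96 log units; beyond the scatter).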

Compound 4, dissociation constant: 7.59 nM
Estimate against measurement, compound 4: 12-fold (1.07 log units) above, and the stated range ends above it.
By their numbers in this assay, from the lowest: compound 4; then compound 3; then compounds 1 and 2 (each within the scatter of the next).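

For the compounds shown here, the exchange of cyclohexyl for 4-acetoxyphenyl on this saturated ring carbon gives, in this assay, a 110-fold lower number from compound 2 to compound 4 (2.03 log units; beyond the scatter), which shows that the position can yield far more than the earlier compounds had revealed. The other measured departure from cyclohexyl, an 11-fold lower number from compound 1 to compound 3 (1.03 log units; beyond the scatter), is the smaller of the two steps, but the two steps start from different configurations as drawn, so the gap between them cannot be assigned to the para-free choice of 4-acetoxyphenyl over 4-ethylphenyl alone. With cyclohexyl in place, the configuration at this carbon shifts the number only within the scatter, as a 1.3-fold higher number from compound 1 to compound 2 (0.11 log units; within the scatter) rests on a single difference: the fact that compounds 1 and 2 differ only in the configuration as drawn.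

Whether configuration stays this unimportant once an aromatic ring occupies the position remains open, as the compounds shown offer no pair with the same aromatic group in both configurations. Also open, from the compounds shown here alone, is how much of the large step belongs to the aromatic ring and how much to its acetoxy substituent, a question that a plain phenyl, a 4-hydroxyphenyl or a 4-methoxyphenyl at this position would bear on directly.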